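The source may report more compounds than this note shows. Statements on the series, on what has been measured and on what is new or still open speak of the compounds shown alone.

Three amides sharing one core were measured in an ADME assay on Huh-7 cells (Homo sapiens) for cytotoxicity, read by MTT assay, with a stated time of 72 h; on this read-out lower numbers stand for higher toxicity in this test and higher numbers for lower toxicity in this test. Compound 1 `C/C(=C\c1c[nH]c2ccc(C)cc12)C(=O)Nc1ccc(C(C)(C)C)cc1` gives 28100 nM. Compound 2 `COc1ccc2[nH]cc(/C=C(\C)C(=O)Nc3ccc(C(C)(C)C)cc3)c2c1` differs from compound 1 by methoxy in place of methyl on an aromatic carbon. In this assay compound 2 gives 16400 nM, so that a 1.7-fold lower number from compound 1 to compound 2 (0.23 log units; within the scatter). Compound 3 `C/C(=C\c1c[nH]c2cc(C)ccc12)C(=O)Nc1ccc(C(C)(C)C)cc1` has the same atoms as compound 1 joined differently; the difference between the two cores is not broken down here. In this assay compound 3 gives 25600 nM, which lies within the scatter of both compound 1 and compound 2, so no order among the three can be read from these numbers.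

Compound 4 `COc1ccc2c(/C=C(\C)C(=O)Nc3ccc(C(C)(C)C)cc3)c[nH]c2c1` has not yet been measured. For the measured compounds named here, it differs from compound 3 by methoxy in place of methyl on an aromatic carbon, which is the same change, at the same place, as the one from compound 1 to compound 2. Its result in this assay is therefore expected to echo that earlier step. Resting on a 1.7-fold lower number from compound 1 to compound 2 (0.23 log units; within the scatter), the expected step is a 1.7-fold lower number from compound 3 to compound 4 (0.23 log units; within the scatter). Going by the values given here, compound 4 is accordingly estimated at 15000 nM, with a likely range from 7000 nM to 35000 nM, the single measured pair being the only guide.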

Compound 4, half-maximal cytotoxic concentration: 30700 nM
Estimate against measurement, compound 4: 2.0-fold (0.31 log units) below; the range from low to high includes it.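

In this assay, methoxy in place of methyl gives a 1.2-fold higher number from compound 3 to compound 4 (0.08 log units; within the scatter), and this new step does not differ from the earlier one beyond what repeated measurements would allow: the same change on two cores in this assay, a 1.7-fold lower number (0.23 log units; within the scatter) from compound 1 to compound 2 and a 1.2-fold higher number (0.08 log units; within the scatter) from compound 3 to compound 4, 2.1-fold (0.31 log units) apart, within the scatter of two such steps. The change therefore carries between these two cores only in a limited sense: on neither core does it move the number beyond the scatter, and the two steps cannot be told apart. This does not establish a fixed size or direction for the change, nor does it show that the change would stay this small on any other core in the series, as the comparison rests on just two pairs.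

The compounds shown leave open what an amine, a chlorine or a carboxylic acid would do in place of the methyl or methoxy on this aromatic carbon in this assay. As far as these compounds go, all four compounds also share the same amide part, so the effect of replacing it with a longer chain remains open too.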